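A few compounds are considered here, and "the series" means these few. Any claim that something is new, unique, unknown or untested is made for them only; others in the source may bear on it.

Measured compounds:
- compound 1 `CCCc1nc(CC)c(C(=O)OCCCOCc2ccccc2)n1Cc1ccc(-c2ccccc2S(=O)(=O)NC(=O)OCCC(C)C)cc1F` — 2 nM in an assay on isolated protein for binding affinity to Type-2 angiotensin II receptor (Homo sapiens); on this read-out higher numbers stand for weaker inhibition and lower numbers for stronger inhibition
- compound 2 `CCCc1nc(CC)c(C(=O)OCCC[S+]([O-])c2ccccc2)n1Cc1ccc(-c2ccccc2S(=O)(=O)NC(=O)OCCC(C)C)cc1F` — 1 nM in this assay
- compound 3 `CCCc1nc(CC)c(C(=O)OCCCCOc2ccccc2)n1Cc1ccc(-c2ccccc2S(=O)(=O)NC(=O)OCCC(C)C)cc1F` — 2 nM in this assay

Compound 3 stands level with compound 1 at the digits shown, the two together the highest of the three numbers; the step of no change at the digits printed from compound 1 to compound 3 (within the scatter) and the step of a 2.0-fold higher number from compound 2 to compound 3 (0.30 log units; within the scatter) both stay within the scatter. All three compounds share the same core and differ only in the group on a saturated chain carbon, three bonds along the chain from an oxygen next to a carbonyl group.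

Compound 4 `CCCc1nc(CC)c(C(=O)OCCCN2C(=O)c3ccccc3C2=O)n1Cc1ccc(-c2ccccc2S(=O)(=O)NC(=O)OCCC(C)C)cc1F` carries the change (a group of 11 heavy atoms (8 carbon, 1 nitrogen, 2 oxygen; one five-membered non-aromatic ring with 1 hetero atom, one six-membered aromatic ring of carbon only) in place of a group of 8 heavy atoms (7 carbon, 1 oxygen; one six-membered aromatic ring of carbon only), on a saturated chain carbon, three bonds along the chain from an oxygen next to a carbonyl group). Among the compounds with values here, the steps that bear on it are the three swaps at the same place: a 2.0-fold lower number from compound 1 to compound 2 (0.30 log units; within the scatter), no change at the digits printed from compound 1 to compound 3 (within the scatter) and a 2.0-fold higher number from compound 2 to compound 3 (0.30 log units; within the scatter), none beyond the scatter. Within the data shown here, the entering group is larger than those tried so far, so no measured step covers it directly; on the evidence at hand, no step beyond the scatter in this assay is expected. Compound 4 is therefore expected at 3 nM, range 1 nM to 10 nM. This estimate means an expected step of a 1.5-fold higher number from compound 3 to compound 4 (0.18 log units; within the scatter).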

Compound 4, half-maximal inhibitory concentration: 3 nM
Compound 4: middle estimate and measured number agree at the digits printed; the range from low to high includes it.
By their numbers in this assay, from the lowest: compounds 2, 1, 3 and 4 (each within the scatter of the next, the first and the last beyond it).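

In this assay, the place on a saturated chain carbon, three bonds along the chain from an oxygen next to a carbonyl group, also accepts the group of 11 heavy atoms with its five-membered non-aromatic ring: a 1.5-fold higher number from compound 3 to compound 4 (0.18 log units; within the scatter) and a 1.5-fold higher number from compound 1 to compound 4 (0.18 log units; within the scatter) both stay within the scatter. Within the data shown here, the first step beyond the scatter at this place is a 3.0-fold higher number from compound 2 to compound 4 (0.48 log units; beyond the scatter), which is modest, and compound 1 and compound 3 go against any clean ordering, each lying within the scatter of both compound 2 and compound 4. Nothing available gives a reason for that step.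

As far as these compounds go, every group here contains a six-membered aromatic ring of carbon only, so it remains open whether a carboxylic acid or an amine in its place would hold these numbers. From the compounds shown here alone, the effect of a plain alkyl chain there also remains open.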